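The source may hold more compounds than are shown below. What is called first, only, known or untested is meant among the compounds shown, and "the series" means these compounds.

In an ADME assay on the whole organism (Mus musculus, strain CD1) for pharmacokinetics, read by LC-MS, with a stated time of 24 h, at a dose of 5 mg/kg by the oral route (a lower number here means less compound in the circulation, a higher number more compound in the circulation at the dose given), compound 3 (`CCC(C(=O)O)c1nn(Cc2cn3cc(OCC4CC4)c(Cl)cc3n2)c2ccccc2c1=O`) gives 1260 ng.h/mL. That lies within the scatter of compound 1 (`O=C(O)Cc1nn(Cc2cn3cc(OCC4CC4)c(Cl)cc3n2)c2ccccc2c1=O`) at 968 ng.h/mL, whereas compound 2 (`C[C@H](C(=O)O)n1nc(Cn2cc3cc(OCC4CC4)c(Cl)cc3n2)c2ccccc2c1=O`) stands clearly higher at 5510 ng.h/mL.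

Compound 4 (`C[C@H](C(=O)O)c1nn(Cc2cn3cc(OCC4CC4)c(Cl)cc3n2)c2ccccc2c1=O`) carries 1-carboxyethyl in place of 1-carboxypropyl on an aromatic carbon.

Going by the values given here, the one measured step that bears on this change is a 1.3-fold higher number from compound 1 to compound 3 (0.11 log units; within the scatter), with ethyl in place of hydrogen on the saturated chain carbon. Across that whole span the number stays within the scatter, and the chain of compound 4 falls inside the span. Among the compounds with values here, no measured step links compound 4 to compound 2, so the 5510 ng.h/mL of compound 2 serves only to widen the upper side of the range.

No change beyond the scatter is therefore expected in this assay, and the expected size is a 1.1-fold higher number from compound 3 to compound 4 (0.05 log units; within the scatter). Compound 4 is estimated at 1400 ng.h/mL, with an expected range of 650 ng.h/mL to 3500 ng.h/mL.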

Compound 4, area under the concentration-time curve: 2790 ng.h/mL
Estimate against measurement, compound 4: 2.0-fold (0.30 log units) below; the range from low to high includes it.
By their numbers in this assay, from the lowest: compounds 1 and 3 (each within the scatter of the next); then compounds 4 and 2 (each within the scatter of the next).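

In this assay the chain carbon proves more responsive than the earlier step suggested: a 1.3-fold higher number from compound 1 to compound 3 (0.11 log units; within the scatter) for ethyl, but a 2.9-fold higher number from compound 1 to compound 4 (0.46 log units; beyond the scatter) for methyl, and a 2.2-fold higher number from compound 3 to compound 4 (0.35 log units; beyond the scatter) for 1-carboxyethyl in place of 1-carboxypropyl. Among hydrogen, methyl and ethyl on this carbon the number therefore does not follow chain length in one direction, with compound 3 going against any steady rise, and compound 4 also carries a defined stereocentre. Nothing measured here explains the difference between the two chains.

Whether the higher number belongs to the methyl group itself or to its configuration stays open, since the mirror-image 1-carboxyethyl compound is not among those shown. Also open, going by these compounds, is how two methyl groups or a cyclopropyl ring on this carbon would read in this assay.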